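This account rests on a few compounds, and the source may have more. Where it says the series, first, only, none or still open, it means among the compounds named here.

Measured compounds in a functional assay on THP-1 cells (Homo sapiens) for inhibition, read by sulforhodamine B assay, with a stated time of 48 h, tested at 50 uM; on this read-out higher numbers stand for more inhibition of growth at the one concentration tested and lower numbers for less inhibition of growth:
compound 1, `COc1ccccc1/C=C/C(=O)/C=C/c1ccc(OCc2cn(CCCCOc3cc(=O)oc4ccccc34)nn2)c(OC)c1`, gives 40%
compound 2, `COc1cc(/C=C/C(=O)/C=C/c2cc(OC)c(OC)c(OC)c2)ccc1OCc1cn(CCCCCOc2cc(=O)oc3ccccc23)nn1`, gives 55%
compound 3, `COc1cccc(/C=C/C(=O)/C=C/c2ccc(OCc3cn(CCCOc4cc(=O)oc5ccccc45)nn3)c(OC)c2)c1`, gives 58%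

Compound 2 stands second highest of the three numbers. Its nearest neighbour is compound 3, whose number lies slightly higher but within the scatter, so no order between compound 2 and compound 3 can be read. Compound 1 lies clearly lower than compound 2, beyond the scatter, and is the furthest of the three.

Compound 4, `COc1cc(/C=C/C(=O)/C=C/c2cccc3ccccc23)ccc1OCc1cn(CCCCCOc2cc(=O)oc3ccccc23)nn1`, is not yet measured. It differs from compound 2 at a single place: naphthalen-1-yl in place of 3,4,5-trimethoxyphenyl on a double-bonded chain carbon bound to a double-bonded chain carbon. Within the data shown here, no pair among the measured compounds differs in exactly one place, so no measured step gives a size for a change of this kind. In this assay the step is therefore expected to be modest, most likely a small drop, possibly no more than the scatter. Compound 4 is expected to give about 45%, with a range from 25% to 65%. The expected step of a number 10 percentage points lower from compound 2 to compound 4 (within the scatter) is accordingly estimated to be small and downward.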

Compound 4, percent growth inhibition at one concentration: 44%
Beside the measured number, compound 4's estimate is 1 percentage points above it, within the range that was stated.
By their numbers in this assay, from the lowest: compounds 1 and 4 (each within the scatter of the next); then compounds 2 and 3 (each within the scatter of the next).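

In this assay, the position on a double-bonded chain carbon bound to a double-bonded chain carbon now has its first readable step: naphthalen-1-yl in place of 3,4,5-trimethoxyphenyl gives a number 11 percentage points lower from compound 2 to compound 4 (beyond the scatter). The change is modest, so growth inhibition at this position does not depend entirely on the 3 hydrogen-bond acceptors of the leaving group, and it persists with a carbon-only group of 2 six-membered aromatic rings. No available evidence accounts for the step.

This single exchange alters the oxygen count and the ring count together, so a plain phenyl, a dimethylaminophenyl or a pyridinyl group at this place would be needed to separate the two. Going by these compounds, the effect of the linker cannot be read, as compounds 1, 2 and 3 differ in more than one place, and a longer chain remains open as well.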